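Swapping the Amide Side Chain of a Melanocortin Receptor 4 Ligand

The source may report more compounds than this note shows. Statements on the series, on what has been measured and on what is new or still open speak of the compounds shown alone.

Of the compounds shown here, two have been measured in an assay on HEK293 cells for displacement of a labelled ligand from Melanocortin receptor 4 (Homo sapiens); on this read-out lower numbers stand for stronger inhibition and higher numbers for weaker inhibition. Compound 1, `CC(C)C[C@H](N)c1cc(C(F)(F)F)ccc1N1CCN(C(=O)CC(C)C(=O)c2ccc(Cl)cc2)CC1`, gives 1100 nM in this assay, the higher of the two numbers, so it is the weaker binder of the pair. Compound 2, `CC(C)C[C@H](N)c1cc(F)ccc1N1CCN(C(=O)C(C)Cc2ccc(Cl)cc2)CC1`, gives 390 nM in this assay, a lower number whose gap to compound 1 lies beyond the usual scatter. Going by the values given here, no step between measured compounds that differ in a single place is available, so the third compound is judged on the structural change and on the spread of the two numbers alone.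

Compound 3, `Cc1ccc(CC(C)C(=O)N2CCN(c3ccc(C(F)(F)F)cc3[C@@H](N)CC(C)C)CC2)cc1C`, keeps the core of compound 1 and alters only the group on the carbonyl carbon: 1-(3,4-dimethylbenzyl)ethyl in place of 2-((4-chlorophenyl)carbonyl)propyl on a carbonyl carbon. The group that leaves carries one hydrogen-bond acceptor and one double bond outside aromatic rings; the group that enters carries neither. Since compound 2 reaches 390 nM with a different side chain, a change at this part of compound 1 can plausibly move the number by a similar amount. The step expected here, a 2.8-fold lower number from compound 1 to compound 3 (0.44 log units; beyond the scatter), is a moderate one toward stronger binding, beyond the scatter. Compound 3 is therefore estimated at 400 nM, with a likely range from 120 nM to 1300 nM.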

Compound 3, inhibition constant: 240 nM
For compound 3 the middle estimate is 1.7-fold (0.22 log units) above the measured one, within the range that was stated.
By their numbers in this assay, from the lowest: compounds 3 and 2 (each within the scatter of the next); then compound 1.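

In this assay, going by these compounds alone, the group on the carbonyl carbon is the first place where a single change can be read: 1-(3,4-dimethylbenzyl)ethyl in place of 2-((4-chlorophenyl)carbonyl)propyl gives a modest step toward stronger binding (a 4.6-fold lower number from compound 1 to compound 3 (0.66 log units; beyond the scatter)). The number therefore responds to this side chain while the rest of the core of compound 1 stays fixed, and in this pair, binding improves even though the entering group has neither the hydrogen-bond acceptor nor the double bond of the group that leaves. The swap alters several features at once, including the chlorine, the carbonyl and the two methyl groups, and no measurement here shows which of them accounts for the step.

Still open, from the compounds shown here alone, is how each feature contributes alone, for instance how a side chain that differs from compound 3 only by a chlorine in place of the two methyl groups would compare. The compounds shown also leave open how far this place tolerates quite different groups, such as an amine, a carboxylic acid or a longer chain.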